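The source may report more compounds than this note shows. Statements on the series, on what has been measured and on what is new or still open speak of the compounds shown alone.

In a functional assay on MDA-MB-231 cells (Homo sapiens) for inhibition (on this read-out lower numbers stand for stronger inhibition and higher numbers for weaker inhibition), compound 3 (`O=C(/C=C/c1ccc(I)cc1)c1ccc(O)cc1`) gives 8000 nM. Compound 2 (`O=C(/C=C/c1ccc(F)c(Cl)c1)c1ccc(B(O)O)cc1`) gives 8500 nM, which lies within the scatter of compound 3. Compound 1 (`O=C(/C=C/c1ccc(B(O)O)cc1)c1ccc[nH]1`) gives 23000 nM, a clearly higher number than that of compound 3 and beyond the scatter. Compound 3 therefore sits in the better pair of this small set, level with compound 2.

The next compound to be measured, compound 4 (`O=C(/C=C/c1ccc(I)cc1)c1ccc(B(O)O)cc1`), keeps the rest of compound 3 but exchanges the hydroxy for a group containing boron and oxygen, on an aromatic carbon of a six-membered aromatic ring of carbon only, para to a large group: a group of 3 heavy atoms (1 boron, 2 oxygen; no ring) in place of one oxygen atom, on an aromatic carbon. Going by the values given here, no measured pair isolates this exchange. The nearest guide is compound 2, which bears the boron group in that same place and gives 8500 nM, close to the value of compound 3. No change beyond the scatter is therefore expected in this assay. The expected step is a 1.1-fold lower number from compound 3 to compound 4 (0.06 log units; within the scatter). The estimated value for compound 4 is 7000 nM, with an expected range from 2800 nM to 17000 nM.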

Compound 4, half-maximal inhibitory concentration: 8800 nM
For compound 4 the middle estimate is 1.3-fold (0.10 log units) below the measured one; low and high end bracket the measured number.
By their numbers in this assay, from the lowest: compounds 3, 2 and 4 (each within the scatter of the next); then compound 1.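

In this assay, replacing the hydroxy with the group of boron and oxygen, with the rest of the molecule held constant, gives a 1.1-fold higher number from compound 3 to compound 4 (0.04 log units; within the scatter), a step within the scatter. Going by these compounds alone, this is the first pair in the set to isolate this exchange. On an aromatic carbon of a six-membered aromatic ring of carbon only, para to a large group, the two groups cannot be told apart by this read-out, at least with this rest of the molecule.

As far as these compounds go, whether an amine or a carboxylic acid in the same place would also stay within the scatter of these two groups remains open. Nothing measured among these compounds offers an explanation for why the two groups cannot be told apart.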